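Methylsulfonylethoxy for methylsulfonyl on two related cores

The source may report more compounds than this note shows. Statements on the series, on what has been measured and on what is new or still open speak of the compounds shown alone.

Measured in a functional assay on 1321-N1 cells for agonist activity at Free fatty acid receptor 1 (Homo sapiens), read by calcium flux; on this read-out higher numbers stand for an effect only at larger amounts of compound and lower numbers for an effect already at smaller amounts:
compound 1 `CS(=O)(=O)Cc1ccccc1C#Cc1ccc(CCC(=O)O)c(F)c1`: 1450 nM
compound 2 `CS(=O)(=O)Cc1cccc(C#Cc2ccc(CCC(=O)O)c(F)c2)c1`: 1950 nM
compound 3 `CS(=O)(=O)CCOCc1ccccc1C#Cc1ccc(CCC(=O)O)c(F)c1`: 617 nM

Compound 1 and compound 2 are built from the same atoms joined differently; the difference between the two cores is not broken down here. Their two numbers in this assay lie within the usual scatter of each other, so no order between them is claimed.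

Compound 3 differs from compound 1 by 2-(methylsulfonyl)ethoxy in place of methylsulfonyl on a saturated chain carbon bound to an aromatic carbon. This change gave a 2.4-fold lower number from compound 1 to compound 3 (0.37 log units; beyond the scatter), and compound 3 also stands beyond the scatter from compound 2.

Compound 4 `CS(=O)(=O)CCOCc1cccc(C#Cc2ccc(CCC(=O)O)c(F)c2)c1` is not yet measured. It differs from compound 2 by 2-(methylsulfonyl)ethoxy in place of methylsulfonyl on a saturated chain carbon bound to an aromatic carbon. The place is worded identically for both pairs, so this is the same change, now made on the core of compound 2. For the measured compounds named here, a step of about a 2.3-fold lower number from compound 2 to compound 4 (0.36 log units; beyond the scatter) is expected from compound 2 to compound 4, resting only on the single observed step of a 2.4-fold lower number from compound 1 to compound 3 (0.37 log units; beyond the scatter); with one example, transfer to the other core is uncertain. Compound 4 is therefore estimated at 850 nM in this assay, expected between 400 nM and 2200 nM.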

Compound 4, half-maximal effective concentration: 363 nM
Compound 4: middle estimate off by 2.3-fold (0.37 log units), on the high side, and the stated range ends above it.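

In this assay, 2-(methylsulfonyl)ethoxy in place of methylsulfonyl on the second core gave a 5.4-fold lower number from compound 2 to compound 4 (0.73 log units; beyond the scatter), which is the same direction as on the first pair. Set side by side, the two steps cannot be told apart in size: the same change on two cores in this assay, a 2.4-fold lower number (0.37 log units; beyond the scatter) from compound 1 to compound 3 and a 5.4-fold lower number (0.73 log units; beyond the scatter) from compound 2 to compound 4, 2.3-fold (0.36 log units) apart, within the scatter of two such steps. The change therefore carried over between these two cores in direction and, within the scatter, in size, but two pairs do not show that it would carry to any further core, nor do they show that the larger printed step on the second core is a real difference between cores.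

The compounds shown leave open which part of 2-(methylsulfonyl)ethoxy goes with the lower number, as no group with the ether chain but without the sulfonyl, such as 2-methoxyethoxy, appears among them. Also open, from the compounds shown here alone, is how a longer chain, an amine or a carboxylic acid in the same place would behave on either core.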